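Working notes: from compound 3 to compound 4

The source may hold more compounds than are shown below. What is called first, only, known or untested is meant among the compounds shown, and "the series" means these compounds.

Measured in a functional assay on HeLa cells (Homo sapiens) for antiproliferative activity, read by MTT assay, with a stated time of 72 h (a lower number here means a stronger inhibitor, a higher number a weaker inhibitor), each value a limit:
- compound 1 `COc1cc(-c2ncnn2-c2ccc(Cl)cc2Cl)cc(OC)c1OC` gives > 10000 nM as a limit
- compound 2 `COc1cc(-c2ncnn2-c2cccc(N)c2)cc(OC)c1OC` gives > 10000 nM as a limit
- compound 3 `COc1cc(-c2ncnn2-c2ccc(Cl)cc2)cc(OC)c1OC` gives > 10000 nM as a limit

Compound 3 stands at > 10000 nM, which is a limit of the assay and not a number. Within the data shown here, the series so far offers only the limit of > 10000 nM in this assay, at which 3 of the 3 values shown sit, and no measured value to rank against.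

Compound 4 `COc1ccc(-n2ncnc2-c2cc(OC)c(OC)c(OC)c2)cc1` differs from compound 3 by methoxy in place of chloro on an aromatic carbon, with methoxy in place of chloro on an aromatic carbon, para to a large group. The steps a step that the two limits leave unreadable from compound 1 to compound 3 and a step that the two limits leave unreadable from compound 2 to compound 3 and a step that the two limits leave unreadable from compound 1 to compound 2 all concern the same aryl group on the aromatic nitrogen, yet none gives a size or a direction to carry over. Any expectation therefore rests on that shared limit alone, and a reading for compound 4 at the same limit remains as likely as a measurable number. In this assay the estimated step is an at least 1.6-fold lower number from compound 3 to compound 4 (0.22 log units; that floor lies within the scatter) and its size is weakly founded, with any change expected towards stronger inhibition. For compound 4 the expected value is 6000 nM within an estimated range of 600 nM to 10000 nM in this series.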

Compound 4, half-maximal inhibitory concentration: > 10000 nM
Compound 4 gave a limit, no number (the forecaster's own chance of this, stated with the estimate: 55%); at least 1.6-fold (0.22 log units) between middle value and limit.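

In this assay, among these compounds, compound 4 gives > 10000 nM, a limit of the assay and not a number, so no step among compound 1, compound 2, compound 3 and compound 4 can be read. The series rests on one limit: the limit of > 10000 nM in this assay, at which 4 of the 4 values shown sit.

The compounds shown leave open how far each lies from that limit and whether changing the aryl group on the aromatic nitrogen alters the read-out at all.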